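Arylsulfamate series: amino substituent change at the para position

The source may report more compounds than this note shows. Statements on the series, on what has been measured and on what is new or still open speak of the compounds shown alone.

Measured so far:
compound 1, `CN(C)CCN(CCN(C)C)c1ccc(C(=O)N2CCc3ccc(OS(N)(=O)=O)cc3C2)cc1` — 15.9%
compound 2, `NS(=O)(=O)Oc1ccc2c(c1)CN(C(=O)c1ccc(N(Cc3ccccc3)Cc3ccco3)cc1)CC2` — 98.2%

In an assay on HEK293 cells for inhibition of Steryl-sulfatase (Homo sapiens), tested at 1 uM (on this read-out lower numbers stand for a weaker effect and higher numbers for a stronger effect at the one concentration tested), compound 1 gives 15.9%, the lowest of the two numbers recorded; in this assay compound 2 gives 98.2%, a number far above compound 1 and well beyond the scatter. The two compounds share the same core and differ only in the amino substituent on the benzoyl ring, so the amino group matters strongly here.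

Compound 3, `CCN(Cc1ccccn1)c1ccc(C(=O)N2CCc3ccc(OS(N)(=O)=O)cc3C2)cc1`, has not been measured. It differs from compound 1 in one place: ethyl((pyridin-2-yl)methyl)amino in place of bis(2-(dimethylamino)ethyl)amino on an aromatic carbon. Compound 3 thus carries an arylmethyl group on the amino nitrogen, as does compound 2, though with a smaller second substituent. An upward step is expected, estimated as a number 54.1 percentage points higher from compound 1 to compound 3 (beyond the scatter), beyond the scatter, because compound 2 reaches 98.2% with arylmethyl groups on that nitrogen. For compound 3 the expected inhibition in this assay is 70%, within the range 35% to 95%.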

Compound 3, a percentage reported as inhibition, at one concentration (the size of the read-out at that concentration, not a potency): 87.7%
The estimate for compound 3 lay 17.7 percentage points below the measured number, and the stated range covers the measured number.
By their numbers in this assay, from the lowest: compound 1; then compound 3; then compound 2.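

In this assay, ethyl((pyridin-2-yl)methyl)amino in place of bis(2-(dimethylamino)ethyl)amino gives a number 71.8 percentage points higher from compound 1 to compound 3 (beyond the scatter) with nothing else changed on the shared core. This single change shows that the read-out at this position depends on the amino substituent itself, and that a group with one six-membered aromatic ring and an ethyl arm reaches a high level where the two open chains do not. The step alone cannot separate the loss of the dimethylamino groups from the gain of the ring, and nothing measured here gives a cause.

From the compounds shown here alone, whether the pyridine ring nitrogen contributes remains open, and a benzyl group in place of the pyridin-2-ylmethyl group would address that. Also open, going by these compounds, is the effect of a single 2-(dimethylamino)ethyl chain paired with the ethyl group.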